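The source may hold more compounds than are shown below. What is called first, only, known or untested is meant among the compounds shown, and "the series" means these compounds.

Measured in a functional assay on MCF7 cells (Homo sapiens) for antiproliferative activity, read by sulforhodamine B assay, with a stated time of 48 h; on this read-out lower numbers stand for stronger inhibition and higher numbers for weaker inhibition:

- compound 1 `O=C1NCCN1c1ccc(S(=O)(=O)Nc2ccc(F)cc2)cc1`: 690 nM
- compound 2 `O=C1NCCN1c1ccc(S(=O)(=O)Nc2ccc(Br)cc2)cc1`: 240 nM

Compound 2 holds the lower of these two numbers, and its gap to compound 1 lies beyond the scatter. Compound 3 `CCCCCCOc1ccc(NS(=O)(=O)c2ccc(N3CCNC3=O)cc2)cc1` has not yet been measured. It carries hexyloxy in place of bromo on an aromatic carbon, para to a large group (hexyloxy in place of bromo on an aromatic carbon).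

Going by the values given here, only one measured step bears on this change: a 2.9-fold lower number from compound 1 to compound 2 (0.46 log units; beyond the scatter), a modest step that puts bromo in place of fluoro at the same kind of position. Among the compounds with values here, that step swaps one halogen for another, whereas hexyloxy is a chain, and no measured compound carries a chain there. The step is therefore only a loose guide to size and says little about direction. In this assay, the likeliest outcome is no step beyond the scatter, though a wide margin on either side is expected. The expected change is a 1.5-fold higher number from compound 2 to compound 3 (0.16 log units; within the scatter). For compound 3 the estimated value is 350 nM, with an expected range from 80 nM to 1500 nM.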

Compound 3, half-maximal inhibitory concentration: > 1000 nM
Compound 3 was reported as a limit (the forecaster's own chance of this, stated with the estimate: 5%); middle value at least 2.8-fold (0.45 log units) from the limit.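

In this assay, compound 3 is recorded only as a limit, > 1000 nM, and this is not a number: the limit of > 1000 nM in this assay, at which 1 of the 3 values shown sits. Until now this position had shown only one halogen exchanged for another, and that exchange lowered the number, but hexyloxy in place of bromo reverses the direction, with an at least 4.1-fold higher number from compound 2 to compound 3 (0.61 log units; beyond the scatter), so the gain from fluoro to bromo does not carry over to this chain. The comparison with the fluoro end of the series reads an at least 1.4-fold higher number from compound 1 to compound 3 (0.16 log units; that floor lies within the scatter), which means that hexyloxy gives up the whole of the gain from bromo, while the data cannot say how far it falls short of fluoro.

The compounds shown leave open how far above the limit the true value of compound 3 lies, and whether the loss belongs to the length of the chain or to the oxygen that joins it to the ring. A short ether such as methoxy, an all-carbon chain such as hexyl, or a further halogen such as chloro or iodo would each bear on these questions, and none of them is among the compounds shown.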